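This account rests on a few compounds, and the source may have more. Where it says the series, first, only, none or still open, it means among the compounds named here.

The series shares one core, shown for compound 1 `COc1ccc(N(Cc2ccccc2)Cc2ccccc2OC)cc1` and compound 2 `COc1ccc(N(Cc2ccccc2)Cc2ccc([N+](=O)[O-])cc2)cc1`, both measured, while compound 3 `COc1ccc(N(Cc2ccccc2)Cc2ccccc2)cc1` remains unmeasured. In a functional assay on L929 cells (Mus musculus) for inhibition, read by MTT assay, with a stated time of 5 days (a lower number here means a stronger inhibitor, a higher number a weaker inhibitor), compound 1 gives only a limit of the assay, > 40 ug/mL. In this assay compound 2 likewise gives only a limit of the assay, > 40 ug/mL. Compound 2 therefore stands at the boundary of what this assay reports, and both values shown sit at that same point (the limit of > 40 ug/mL in this assay, at which 2 of the 2 values shown sit). Going by the values given here, no step between measured compounds can be stated: compound 1 and compound 2 differ in more than one place, and neither yields a number. The change from compound 2 to compound 3 is hydrogen in place of nitro on an aromatic carbon, in words hydrogen in place of nitro on an aromatic carbon. Without a measured step to lean on, no shift beyond the scatter is expected in either direction in this assay. The step is expected as a step that the limit leaves unreadable from compound 2 to compound 3. Compound 3 is expected to come out near 60 ug/mL, within a range from 20 ug/mL to 200 ug/mL, most likely reported again only as a limit of the assay.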

Compound 3, half-maximal inhibitory concentration: 12 ug/mL
For compound 3 the middle estimate is 5.0-fold (0.70 log units) above the measured one; measured number below the stated range.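

In this assay, going by these compounds alone, compound 3 gives 12 ug/mL as the first reading that is a number and not a limit. Hydrogen in place of nitro on an aromatic carbon, para to a large group, gives an at least 3.3-fold lower number from compound 2 to compound 3 (0.52 log units; beyond the scatter) and exchanging methoxy for hydrogen gives an at least 3.3-fold lower number from compound 1 to compound 3 (0.52 log units; beyond the scatter) so that in these two comparisons the compound carrying hydrogen has the lower number, beyond the scatter in both. Each step gives only a lower bound on its size, because compound 1 and compound 2 both stop at the limit of the assay: the limit of > 40 ug/mL in this assay, at which 2 of the 3 values shown sit.

Within the data shown here, the full size of the nitro and methoxy effects on the number cannot be read from these compounds, and no step between compound 1 and compound 2 can be read either. From the compounds shown here alone, whether an amine, a carboxylic acid or a longer chain at this position would keep the number of compound 3, lower it or raise it stays open, and with a single numerical value the series offers no trend across substituents.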